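This account rests on a few compounds, and the source may have more. Where it says the series, first, only, none or still open, it means among the compounds named here.

Measured compounds:
- compound 1, `C=C1C(=O)OC[C@H]1CCOC(=O)Nc1c(C)cccc1C(C)C`, 22200 nM
- compound 2, `C=C1C(=O)OC[C@@H]1CCOC(=O)Nc1ccc(C)c(C)c1`, 13700 nM

In an ADME assay on RAW264.7 cells (Mus musculus) for cytotoxicity, read by MTT assay, with a stated time of 18 h (a lower number here means that less compound is tolerated, a higher number that more compound is tolerated), compound 2 gives 13700 nM, and compound 1 gives 22200 nM; these two numbers sit within the usual scatter of each other, so neither can be called more or less tolerated. The untested compound 3, `C=C1C(=O)OC[C@H]1CCOC(=O)Nc1ccc(C)c(C)c1`, differs from compound 2 only in this way: the two compounds have the same atoms and bonds and differ only in configuration as drawn: 1 of 1 stereo elements differ; a stereocentre at a saturated ring carbon is drawn R in compound 2 and S in compound 3. Going by the values given here, with no measured pair of mirror-image compounds to learn from, no step beyond the scatter is expected here, in either direction. Compound 3 is therefore estimated at 15000 nM, with a range from 7000 nM to 32000 nM, meaning an expected step of a 1.1-fold higher number from compound 2 to compound 3 (0.04 log units; within the scatter).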

Compound 3, half-maximal cytotoxic concentration: 18200 nM
Beside the measured number, compound 3's estimate is 1.2-fold (0.08 log units) below it; the measured number falls inside the stated range.
By their numbers in this assay, from the lowest: compounds 2, 3 and 1 (each within the scatter of the next).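

This pair gives the first measured view of what the configuration at this saturated ring carbon does, since nothing else separates the two compounds: the fact that compounds 2 and 3 differ only in the configuration as drawn. In this assay, changing the stereocentre from R to S gives a 1.3-fold higher number from compound 2 to compound 3 (0.12 log units; within the scatter). For this pair, then, the configuration as drawn makes no difference that can be told apart from the usual variation between repeated measurements.

Going by these compounds, whether that holds for other compounds stays open, for example once an amine or a carboxylic acid is added to the shared core.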